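Chloro in Place of Methyl on a Saturated Ring

The compounds below may be only part of what the source reports. "The series", "measured", "known", "first", "only" and "open" are said of these compounds alone.

Compound 1, `CC1CC=C(C(=O)N(c2cc(C#CC(C)(C)C)sc2C(=O)O)C(C)C)CC1`, in an ADME assay on MT4 cells (Homo sapiens) for cytotoxicity, with a stated time of 5 days (on this read-out lower numbers stand for higher toxicity in this test and higher numbers for lower toxicity in this test), gives > 20000 nM, which is a limit of the test and not a number.
Compound 2, `CC(C)N(c1cc(C#CC(C)(C)C)sc1C(=O)O)C(=O)[C@H]1CC[C@H](C)CC1`, gives > 20000 nM in this assay, again only a limit.
Compound 3, `CC(C)(C)C#Cc1cc(N(CCO)C(=O)[C@H]2CC[C@H](C)CC2)c(C(=O)O)s1`, gives > 20000 nM in this assay, once more a limit.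

Compound 2 therefore stands at the limit of > 20000 nM in this assay, at which 3 of the 3 values shown sit, with no measured number of its own. The unmeasured compound 4, `CC(C)N(c1cc(C#CC(C)(C)C)sc1C(=O)O)C(=O)[C@H]1CC[C@H](Cl)CC1`, differs from compound 2 in one place: chloro in place of methyl on a saturated ring carbon.

Going by the values given here, two measured steps touch compound 2. The step that the two limits leave unreadable from compound 1 to compound 2 and the step that the two limits leave unreadable from compound 2 to compound 3 both end at the same limit, so neither tells how large a change of this kind is in this assay. Among the compounds with values here, nothing among the measured compounds shows a readable move in either direction, and every value rests at the same limit.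

With that, compound 4 is expected to sit at or beyond the limit as well, most likely reported again only as a limit. The step therefore expected reads a step that the limit leaves unreadable from compound 2 to compound 4. Compound 4 is estimated at about 30000 nM, within a range from 15000 nM to 100000 nM.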

Compound 4, half-maximal cytotoxic concentration: > 20000 nM
Compound 4: only a limit was reported; the forecaster's own chance of this, stated with the estimate: 85%; the middle value lies beyond the limit too.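

Compound 4 gives > 20000 nM in this assay, again a limit and not a number. The changes from compound 1 and from compound 2 to compound 4 therefore cannot be read, since all values rest at the same point: the limit of > 20000 nM in this assay, at which 4 of the 4 values shown sit.

The compounds shown leave open at what concentration any of them would harm these cells, and whether chloro and methyl differ there.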